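Permeability of Compound 4 Against Its Three Measured Analogues

A few compounds are considered here, and "the series" means these few. Any claim that something is new, unique, unknown or untested is made for them only; others in the source may bear on it.

Compound 3, `O=C(NCc1cc(Cl)ccc1-n1cnnn1)[C@@H]1CC=NN1C(=O)[C@H](O)C1CCCCC1`, gives 19 10^-6 cm/s in an ADME assay on Caco-2 cells (Homo sapiens) for permeability, read by LC-MS, in the apical to basolateral direction, with a stated time of 60 min, at pH 6.5 (on this read-out higher numbers stand for higher permeability and lower numbers for lower permeability), the highest of the three numbers in hand. Compound 2, `Cc1cccc([C@@H](O)C(=O)N2N=CC[C@H]2C(=O)NCc2cc(Cl)ccc2-n2cnnn2)c1`, gives 9.7 10^-6 cm/s. Compound 1, `CC1(C[C@@H](O)C(=O)N2N=CC[C@H]2C(=O)NCc2cc(Cl)ccc2-n2cnnn2)CC1`, gives 9.5 10^-6 cm/s. The margin of compound 3 to each of the two stays within the scatter. Compound 4, `CC(C)CC[C@@H](O)C(=O)N1N=CC[C@H]1C(=O)NCc1cc(Cl)ccc1-n1cnnn1`, differs from compound 3 in one place: isopentyl in place of cyclohexyl on a saturated chain carbon bound to a carbonyl carbon and an oxygen on a saturated carbon. For the measured compounds named here, the steps that bear on this change are those that alter the same group on a saturated chain carbon bound to a carbonyl carbon and an oxygen on a saturated carbon: a 1.0-fold higher number from compound 1 to compound 2 (0.01 log units; within the scatter), a 2.0-fold higher number from compound 1 to compound 3 (0.30 log units; within the scatter) and a 2.0-fold higher number from compound 2 to compound 3 (0.29 log units; within the scatter), none of them beyond the scatter. Since (1-methylcyclopropyl)methyl, 3-methylphenyl and cyclohexyl at this position all left the permeability close together, one expects the move to isopentyl to do likewise, with a step of about a 1.3-fold lower number from compound 3 to compound 4 (0.10 log units; within the scatter) and no direction beyond the scatter. Compound 4 is therefore estimated at 15 10^-6 cm/s, within a range from 7.5 10^-6 cm/s to 30 10^-6 cm/s.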

Compound 4, apparent permeability: 29 10^-6 cm/s
Beside the measured number, compound 4's estimate is 1.9-fold (0.29 log units) below it; low and high end bracket the measured number.
By their numbers in this assay, from the lowest: compounds 1, 2, 3 and 4 (each within the scatter of the next, the first and the last beyond it).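

In this assay, for the compounds shown here, isopentyl gives the first steps at this position that lie beyond the scatter, though both are modest: a 3.0-fold higher number from compound 2 to compound 4 (0.48 log units; beyond the scatter) and a 3.1-fold higher number from compound 1 to compound 4 (0.48 log units; beyond the scatter), the latter printed as isobutyl in place of 1-methylcyclopropyl. The change from cyclohexyl itself stays within the scatter, at a 1.5-fold higher number from compound 3 to compound 4 (0.18 log units; within the scatter), so on this read-out the position does respond to its group, but isopentyl cannot be separated from cyclohexyl. Nothing in the data given accounts for these differences.

Isopentyl is the only group without a ring at this position, so the compounds shown cannot tell the loss of a ring apart from the branching or the length of the chain. A longer unbranched chain, an amine or a carboxylic acid in this place remains an open case.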